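Methylating the Phenol: What Compound 4 Should Give

The compounds below may be only part of what the source reports. "The series", "measured", "known", "first", "only" and "open" are said of these compounds alone.

Measured compounds:
compound 1 `COc1ccc(/C=C/C2(C)C=CC(=O)O2)c(OC)c1OC`, 349000 nM
compound 2 `COc1c(O)ccc(/C=C/C2(C)C=CC(=O)O2)c1OC`, 51600 nM
compound 3 `CC1(/C=C/c2ccccc2O)C=CC(=O)O1`, 78000 nM

Of the compounds shown here, three have been tested in a functional assay on NCI/ADR-RES cells (Homo sapiens) for inhibition, read by sulforhodamine B assay, with a stated time of 48 h; on this read-out higher numbers stand for weaker inhibition of growth and lower numbers for stronger inhibition of growth. Compound 1 gives 349000 nM, compound 2 gives 51600 nM, and compound 3 gives 78000 nM. Compound 2 and compound 3 lie within the scatter of each other, so nothing can be said about their order, while compound 1 sits clearly higher than both.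

Compound 1 and compound 2 differ in one place: methyl in place of hydrogen on an oxygen on an aromatic ring. This step gave a 6.8-fold higher number from compound 2 to compound 1 (0.83 log units; beyond the scatter) in this assay. Compound 3 and compound 2 differ in more than one place; the difference between their cores is not broken down here.

The unmeasured compound 4 `COc1ccccc1/C=C/C1(C)C=CC(=O)O1` is made from compound 3 by the same kind of change: methyl in place of hydrogen on an oxygen on an aromatic ring. Its place line reads the same as that of the step from compound 2 to compound 1, so the surroundings are not told apart here, although the cores of compound 2 and compound 3 do differ, which leaves it open whether the step will repeat in size.

Resting on the step seen from compound 2 to compound 1 in this assay, namely a 6.8-fold higher number from compound 2 to compound 1 (0.83 log units; beyond the scatter), the account expects a step of about a 5.1-fold higher number from compound 3 to compound 4 (0.71 log units; beyond the scatter) from compound 3 to compound 4. Compound 4 is therefore estimated at 400000 nM, with a likely range from 120000 nM to 1000000 nM, because compound 3 gives 78000 nM.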

Compound 4, concentration for total growth inhibition: 64500 nM
The estimate for compound 4 lay 6.2-fold (0.79 log units) above the measured number; the whole stated range lies above it.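

In this assay, the swap of hydroxy to methoxy on the core of compound 3 gave a 1.2-fold lower number from compound 3 to compound 4 (0.08 log units; within the scatter), so this pair cannot be told apart on this read-out. Set beside the earlier step, the same change does not carry over in size from one core to the other in this series: the same change on two cores in this assay, a 6.8-fold higher number (0.83 log units; beyond the scatter) from compound 2 to compound 1 and a 1.2-fold lower number (0.08 log units; within the scatter) from compound 3 to compound 4, 8.2-fold (0.91 log units) apart, beyond the scatter of two such steps. For the compounds shown here, this shows that the large step seen on the core of compound 2 cannot be taken as a general value for the change, but it does not show which difference between the two cores sets the steps apart, since those cores differ in more than one place and only two steps are at hand.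

The compounds shown leave open whether the further methoxy groups on the core of compound 2 are what separates the two results, and which of the two steps a third core would follow. They also leave open whether a longer chain on that same oxygen, such as ethyl, or an amine in place of the hydroxy would behave like the methyl on either core.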